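The source may report more compounds than this note shows. Statements on the series, on what has been measured and on what is new or still open speak of the compounds shown alone.

Measured in an ADME assay on MDBK cells (Bos taurus) for cytotoxicity, read by MTT assay; on this read-out lower numbers stand for higher toxicity in this test and higher numbers for lower toxicity in this test:
- Compound 1 `CCC1CCC(OCCCCCCN2C[C@H](O)[C@@H](O)[C@H](O)[C@H]2CO)CC1`: > 500000 nM
- Compound 2 `OC[C@@H]1[C@@H](O)[C@H](O)[C@@H](O)CN1CCCc1ccc(OC2CCCCC2)cc1`: 295000 nM
- Compound 3 `CCCCC1CCC(OCCCCCCN2C[C@H](O)[C@@H](O)[C@H](O)[C@H]2CO)CC1`: 190000 nM

The entry for compound 1 is a limit of the assay and not a number. Compound 1 thus stands at the limit of > 500000 nM in this assay, at which 1 of the 3 values shown sits, so only a limit is known for it.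

Compound 4 `CC1CCCC(OCCCCCCN2C[C@H](O)[C@@H](O)[C@H](O)[C@H]2CO)C1C` has not yet been measured in this assay. It departs from compound 1 in a single group: a group of 8 heavy atoms (8 carbon; one six-membered non-aromatic ring of carbon only) in place of a group of 8 heavy atoms (8 carbon; one six-membered non-aromatic ring of carbon only), on an oxygen on a saturated carbon. The two compounds have the same atoms, joined differently, and the shared core stays as it is.

Among the compounds with values here, only one measured step bears on this change, and only indirectly. That step is an at least 2.6-fold lower number from compound 1 to compound 3 (0.42 log units; beyond the scatter), and it adds ethyl in place of hydrogen, whereas the change to compound 4 adds no atoms. Compound 2 differs from the others in more than one place and offers no direct comparison.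

With no added atoms, no step beyond the scatter is expected, although a modest fall in the number cannot be excluded given the measured step to compound 3. The expected change is an at least 1.1-fold lower number from compound 1 to compound 4 (0.07 log units; that floor lies within the scatter). For compound 4 the estimated value is 420000 nM, with an expected range from 190000 nM to 900000 nM.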

Compound 4, half-maximal cytotoxic concentration: > 500000 nM
Compound 4 gave a limit, no number; the forecaster's own chance of this, stated with the estimate: 55%; at least 1.1-fold (0.07 log units) between middle value and limit.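

In this assay, compound 4 gave a limit and not a number, and so did compound 1, which means no step between the two can be read: the limit of > 500000 nM in this assay, at which 2 of the 4 values shown sit.

The compounds shown leave open whether replacing the 4-ethylcyclohexyl group with the group in compound 4 changes the read-out in this assay at all, and in which direction.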